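Swapping a Pyridine Arm in a Glutamate-Receptor Series

The source may report more compounds than this note shows. Statements on the series, on what has been measured and on what is new or still open speak of the compounds shown alone.

Compound 1, `Cc1ccncc1-c1cc(F)cc(-n2nnc(-c3ncc[nH]3)n2)c1`: 3.5 nM
Compound 2, `Cc1c[nH]c(-c2nnn(-c3cc(F)cc(C#N)c3)n2)n1`: 19 nM
Compound 3, `N#Cc1cccc(-n2nnc(-c3ccccn3)n2)c1`: 102 nM

All three were tested in an assay for binding affinity to metabotropic glutamate receptor 5 (Rattus norvegicus); on this read-out lower numbers stand for stronger inhibition and higher numbers for weaker inhibition. Among them compound 3 shows the highest number: compound 2 sits clearly lower and compound 1 lower still, both gaps lying beyond the usual scatter of repeated measurements. Compound 3 is therefore the weakest binder of the three.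

Compound 4, `N#Cc1cccc(-n2nnc(-c3cscn3)n2)c1`, is built from compound 3 by a single change: 1,3-thiazol-4-yl in place of pyridin-2-yl on an aromatic carbon. Among the compounds with values here, no measured pair shows this particular exchange, so there is no step to lean on. Compound 2, which gives 19 nM, carries a five-membered ring in the same position, but it also differs elsewhere, so it offers only a loose hint. The expected step from compound 3 to compound 4 is small, a 1.3-fold lower number from compound 3 to compound 4 (0.11 log units; within the scatter), within the scatter, in no firm direction. Compound 4 is estimated at 80 nM, with a range from 25 nM to 300 nM.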

Compound 4, inhibition constant: 157 nM
For compound 4 the middle estimate is 2.0-fold (0.29 log units) below the measured one; low and high end bracket the measured number.
By their numbers in this assay, from the lowest: compound 1; then compound 2; then compounds 3 and 4 (each within the scatter of the next).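

In this assay, within the data shown here, putting 1,3-thiazol-4-yl in place of pyridin-2-yl gives a 1.5-fold higher number from compound 3 to compound 4 (0.19 log units; within the scatter), the first direct reading of a single change at this position. On this carbon of the ring with four nitrogen atoms, a five-membered aromatic ring with two hetero atoms and a six-membered aromatic ring with one hetero atom therefore cannot be told apart in this assay, even though the new ring brings sulfur and one more hydrogen-bond acceptor by count. No measured property is available to explain this result.

The compounds shown carry only aromatic rings at this position, so how an amine or a carboxylic acid on the same carbon would read remains open. Also open, as far as these compounds go, is whether the same exchange would read alike on the core of compound 1.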